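Sulfonamide aryl swap: difluorophenyl to dimethylphenyl

The source may hold more compounds than are shown below. What is called first, only, known or untested is meant among the compounds shown, and "the series" means these compounds.

Working notes on the series. Compound 2 `O=C1NCCN1c1ccc(S(=O)(=O)Nc2ccc(F)c(F)c2)cc1` carries a 3,4-difluorophenyl on the sulfonamide nitrogen of the shared core, and in a functional assay on M21 cells (Homo sapiens) for antiproliferative activity, read by sulforhodamine B assay, with a stated time of 48 h (on this read-out higher numbers stand for weaker inhibition and lower numbers for stronger inhibition), compound 2 gives 220 nM, the lowest of the two numbers available. Compound 1 `CCCCCc1ccc(NS(=O)(=O)c2ccc(N3CCNC3=O)cc2)cc1` carries a pentyl on an aromatic carbon instead; in this assay compound 1 gives 870 nM, a step beyond the scatter from compound 2. Compound 3 `CCCCCCOc1ccc(NS(=O)(=O)c2ccc(N3CCNC3=O)cc2)cc1`, with hexyloxy in place of pentyl, is reported only as a limit in this assay: compound 3 gives > 1000 nM, which is the limit of > 1000 nM in this assay, at which 1 of the 3 values shown sits. Among the measured compounds shown here, the one measured step, an at least 1.1-fold higher number from compound 1 to compound 3 (0.06 log units; that floor lies within the scatter), concerns hexyloxy in place of pentyl and is bounded only at its floor.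

Compound 4 `Cc1ccc(NS(=O)(=O)c2ccc(N3CCNC3=O)cc2)c(C)c1` differs from compound 2 as follows: 2,4-dimethylphenyl in place of 3,4-difluorophenyl on a sulfonamide nitrogen. For the measured compounds named here, no measured step covers this change; the step from compound 1 to compound 3 concerns a different pair of groups. What the numbers show is that the difluorophenyl of compound 2 sits lowest and the alkyl-bearing compound 1 higher, so a move to a dimethyl-bearing aryl is expected to raise the number, with wide uncertainty. The estimated step is a 3.6-fold higher number from compound 2 to compound 4 (0.56 log units; beyond the scatter). Compound 4 is expected at 800 nM, within 250 nM to 2500 nM.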

Compound 4, half-maximal inhibitory concentration: 150 nM
The estimate for compound 4 lay 5.3-fold (0.73 log units) above the measured number; the measured number lies below the stated range.
By their numbers in this assay, from the lowest: compounds 4 and 2 (each within the scatter of the next); then compound 1. At a limit, above all of these: compound 3.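

On the sulfonamide nitrogen, 2,4-dimethylphenyl in place of 3,4-difluorophenyl gives a 1.5-fold lower number from compound 2 to compound 4 (0.17 log units; within the scatter) in this assay, so the two aryl groups cannot be told apart on this read-out. Fluorine on this aryl ring is thus not needed to keep the number in this range, at least for this pair, since the all-carbon 2,4-dimethylphenyl of compound 4 serves as well as the 3,4-difluorophenyl of compound 2. The higher number of compound 1 at 870 nM also does not extend to every alkyl-bearing aryl in the series, as compound 4 gives 150 nM with its 2,4-dimethylphenyl.

As far as these compounds go, whether one methyl alone would hold the number stays open, as does the outcome for an amine, a carboxylic acid or a chain of intermediate length such as propyl on this aryl ring. Nothing among the data shown accounts for the closeness of compound 2 and compound 4.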